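Swapping the five-membered ring on a shared core

This account rests on a few compounds, and the source may have more. Where it says the series, first, only, none or still open, it means among the compounds named here.

compound 1 `Cc1ncc(-c2ccccc2NCC2=NCCN2)o1`: < 5020 nM
compound 2 `Cc1cc(-c2ccccc2NCC2=NCCN2)on1`: < 100000 nM
compound 3 `c1ccc(-c2cnoc2)c(NCC2=NCCN2)c1`: < 100000 nM

In a functional assay for activation of Alpha-1D adrenergic receptor (Homo sapiens) (a lower number here means that less compound is needed, a higher number that more compound is needed for the effect), compound 1 gives only a limit of the assay, < 5020 nM, not a number. Compound 2 likewise returns only a limit, < 100000 nM. Compound 3 also returns only a limit, < 100000 nM, so where it stands among the three cannot be fixed by a number. The steps between the measured compounds are a step that the two limits leave unreadable from compound 1 to compound 2, a step that the two limits leave unreadable from compound 1 to compound 3 and a step that the two limits leave unreadable from compound 2 to compound 3; none of them is readable in size or direction. This follows from the limit of < 100000 nM in this assay, at which 2 of the 3 values shown sit, and from the limit of < 5020 nM in this assay, at which 1 of the 3 values shown sits.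

Compound 4 `Cc1noc(-c2ccccc2NCC2=NCCN2)n1` differs from compound 3 by 3-methyl-1,2,4-oxadiazol-5-yl in place of 1,2-oxazol-4-yl on an aromatic carbon. The measured steps that bear on this change all exchange the group on the same aromatic carbon of the shared core, yet every one of them is unreadable, so they give no size and no direction to carry over. For compound 4 in this assay the expected step is therefore a step that the limit leaves unreadable from compound 3 to compound 4, an expectation of no change beyond the scatter, held with wide uncertainty. Compound 4 is estimated at 3000 nM, in a range from 300 nM to 30000 nM, and a further limit instead of a number is quite possible.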

Compound 4, half-maximal effective concentration: < 5020 nM
Compound 4 ended at the assay's limit; the forecaster's own chance of this, stated with the estimate: 60%; the middle value does not contradict the limit.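

Compound 4 gives < 5020 nM as a limit of the assay, not a number. Its steps to compound 1, compound 2 and compound 3 therefore cannot be read in size or direction. Whether the four five-membered rings on the shared core truly differ in this assay is what the compounds shown leave open.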